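The source may report more compounds than this note shows. Statements on the series, on what has been measured and on what is new or still open speak of the compounds shown alone.

In an ADME assay on Akata cells (Homo sapiens) for cytotoxicity, with a stated time of 7 days (on this read-out lower numbers stand for higher toxicity in this test and higher numbers for lower toxicity in this test), compound 1, `CNc1nc(N)nc2c1ncn2/C=C1/CC1(CO)CO`, gives > 24000 nM, which is a limit of the assay. Compound 2, `COCCOc1nc(N)nc2c1ncn2/C=C1/CC1(CO)CO`, gives > 20000 nM, and this too is a limit and not a number. Going by the values given here, compound 2 therefore has no exact position on this scale, and the only other value available to compare it with is likewise a limit.

Compound 3, `CCCCCCCCOc1nc(N)nc2c1ncn2/C=C1/CC1(CO)CO`, keeps the shared core but differs from compound 2 by hexyl in place of methoxy on a saturated chain carbon, two bonds along the chain from an oxygen on an aromatic ring, which turns 2-methoxyethoxy into octyloxy.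

Among the compounds with values here, only one measured step bears on this change, a step that the two limits leave unreadable from compound 1 to compound 2. It introduced the 2-methoxyethoxy group but offers no size to carry forward. The expectation therefore rests on the structural change alone and remains loose, with a moderate move towards lower numbers in this assay judged more likely than a rise. The estimated change is an at least 1.4-fold lower number from compound 2 to compound 3 (0.15 log units; that floor lies within the scatter). Compound 3 is expected to give 14000 nM, with an estimated range from 4000 nM to 40000 nM.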

Compound 3, half-maximal cytotoxic concentration: > 20000 nM
Compound 3: only a limit was reported (the forecaster's own chance of this, stated with the estimate: 45%); middle value at least 1.4-fold (0.15 log units) from the limit.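

In this assay compound 3 gives > 20000 nM, which is a limit of the assay. The steps to compound 3 from compound 2 and from compound 1 therefore cannot be read. The compounds shown leave open where the half-maximal cytotoxic concentration of any of the three lies, and whether methylamino, 2-methoxyethoxy and octyloxy differ in this read-out at all.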